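The source may report more compounds than this note shows. Statements on the series, on what has been measured and on what is new or still open speak of the compounds shown alone.

Values in a functional assay on A-431 cells (Homo sapiens) for antiproliferative activity, read by MTT assay, with a stated time of 72 h; on this read-out lower numbers stand for stronger inhibition and higher numbers for weaker inhibition:
Compound 1 `CN1CCN(Cc2ccc(NC(=O)Nc3ccc4ncnc(Nc5ccc(F)c(Cl)c5)c4c3)cc2)CC1`: 4000 nM
Compound 2 `CN1CCN(Cc2ccc(NC(=O)Nc3ccc4ncnc(Nc5ccc(F)c(F)c5)c4c3)cc2)CC1`: > 10000 nM, a limit of the assay
Compound 3 `COc1ccc(Nc2ncnc3ccc(NC(=O)Nc4ccc(CN5CCN(C)CC5)cc4)cc23)cc1Cl`: 2010 nM

Compound 3 cannot be told apart from compound 1, as the step lies within the scatter: a 2.0-fold lower number from compound 1 to compound 3 (0.30 log units; within the scatter). The step from the limit is beyond the scatter: an at least 4.9-fold lower number from compound 2 to compound 3 (0.69 log units; beyond the scatter).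

Compound 4 `COC(=O)c1cccc(Nc2ncnc3ccc(NC(=O)Nc4ccc(CN5CCN(C)CC5)cc4)cc23)c1` differs from compound 3 on a nitrogen on an aromatic ring: 3-(methoxycarbonyl)phenyl in place of 3-chloro-4-methoxyphenyl on a nitrogen on an aromatic ring. Going by the values given here, no measured compound carries 3-(methoxycarbonyl)phenyl, so the evidence is indirect. The nearest guide is the loss of chloro, which gave an at least 2.5-fold higher number from compound 1 to compound 2 (0.39 log units; beyond the scatter), whereas methoxy in place of fluoro gave only a 2.0-fold lower number from compound 1 to compound 3 (0.30 log units; within the scatter). A modest move to a higher number is therefore expected in this assay, an estimated 2.5-fold higher number from compound 3 to compound 4 (0.40 log units; beyond the scatter). For compound 4 the estimate is 5000 nM, with an expected range of 1800 nM to 14000 nM.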

Compound 4, half-maximal inhibitory concentration: 5630 nM
Compound 4: the middle estimate sits 1.1-fold (0.05 log units) below what was measured; measured number inside the range.
By their numbers in this assay, from the lowest: compounds 3, 1 and 4 (each within the scatter of the next, the first and the last beyond it). At a limit, above all of these: compound 2.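

In this assay, 3-(methoxycarbonyl)phenyl on this nitrogen does worse than 3-chloro-4-methoxyphenyl, with a 2.8-fold higher number from compound 3 to compound 4 (0.45 log units; beyond the scatter) for this change. Against 3-chloro-4-fluorophenyl the step lies within the scatter, so the two cannot be told apart: a 1.4-fold higher number from compound 1 to compound 4 (0.15 log units; within the scatter). Compound 4 gives a measured number without any chloro on the ring. Compound 2 stands at a limit: the limit of > 10000 nM in this assay, at which 1 of the 4 values shown sits. The step from that limit gives a floor that lies within the scatter: an at least 1.7-fold lower number from compound 2 to compound 4 (0.24 log units; that floor lies within the scatter).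

Going by these compounds, whether a carboxylic acid, a primary amide or a nitrile in place of the methoxycarbonyl would keep this number stays open.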